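Changing the aryl group at the limit of growth inhibition

The compounds below may be only part of what the source reports. "The series", "measured", "known", "first", "only" and "open" are said of these compounds alone.

Measured in a functional assay on MCF7 cells (Homo sapiens) for antiproliferative activity, read by MTT assay, with a stated time of 72 h; on this read-out higher numbers stand for weaker inhibition of growth and lower numbers for stronger inhibition of growth:
Compound 1 `Cc1c(C(=O)Nc2ccc(SC#N)cc2)nnn1-c1ccc(C(C)C)cc1`: > 100000 nM (a limit)
Compound 2 `Cc1ccc(Cl)c(-n2nnc(C(=O)Nc3ccc(SC#N)cc3)c2C)c1`: > 100000 nM (a limit)

Compound 2 has no number of its own. Its result of > 100000 nM is a limit. The only other result, for compound 1, is also a limit, so both measured compounds share one position: the limit of > 100000 nM in this assay, at which 2 of the 2 values shown sit.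

Compound 3 `COc1cccc(-n2nnc(C(=O)Nc3ccc(SC#N)cc3)c2C)c1` keeps the shared core and changes a single group: 3-methoxyphenyl in place of 2-chloro-5-methylphenyl on an aromatic nitrogen. Among the compounds with values here, the one measured step that bears on this change is a step that the two limits leave unreadable from compound 1 to compound 2, which exchanged the group on the same aromatic nitrogen. It gives no size to carry over, and it gives no direction either. Within the data shown here, with that step as the only guide, no change beyond the usual scatter is expected in this assay, and a further limit is the most likely report. The estimated change is a number no higher from compound 2 to compound 3 (the limit leaves the size open). For compound 3 the expected value is 100000 nM, with an estimated range of 30000 nM to 300000 nM.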

Compound 3, concentration for 50% growth inhibition: > 100000 nM
Compound 3: a limit, no number; the forecaster's own chance of this, stated with the estimate: 70%; the middle value lies on the limit itself.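

Compound 3 also gives a limit and not a number, so neither the step from compound 2 to compound 3 nor the step from compound 1 to compound 3 can be read, because all three compounds share one position: the limit of > 100000 nM in this assay, at which 3 of the 3 values shown sit.

The compounds shown leave open how these three groups on the aromatic nitrogen rank in growth inhibition, and how large any difference between them is.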